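The source may report more compounds than this note shows. Statements on the series, on what has been measured and on what is new or still open speak of the compounds shown alone.

Three compounds share one core and differ in the chain that carries the hydroxycarbamoyl end. Compound 1 `CC(C)c1cc(-c2n[nH]c(=O)n2-c2cccc(C(=O)NCCCC(=O)NO)c2)c(O)cc1O`, compound 2 `CC(C)c1cc(-c2n[nH]c(=O)n2-c2cccc(C(=O)NCCCCC(=O)NO)c2)c(O)cc1O` and compound 3 `CC(C)c1cc(-c2n[nH]c(=O)n2-c2ccc(C(=O)NCCCCC(=O)NO)cc2)c(O)cc1O` have each been tested in a functional assay on HEL cells (Homo sapiens) for inhibition; a higher number here means a weaker inhibitor, a lower number a stronger inhibitor. In this assay compound 1 gives 4600 nM. In this assay compound 2 gives 4600 nM. In this assay compound 3 gives 4600 nM. The change from compound 2 to compound 1, (hydroxycarbamoyl in place of (hydroxycarbamoyl)methyl on a saturated chain carbon, three bonds along the chain from an amide-type nitrogen), made a step of no change at the digits printed from compound 2 to compound 1 (within the scatter). Compound 3 has the same atoms as compound 2, joined differently; the difference between the two cores is not broken down here. Compound 3 and compound 1 read the same at the digits given, and so do compound 3 and compound 2.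

Compound 4 `CC(C)c1cc(-c2n[nH]c(=O)n2-c2ccc(C(=O)NCCCC(=O)NO)cc2)c(O)cc1O` has not yet been measured. It differs from compound 3 by hydroxycarbamoyl in place of (hydroxycarbamoyl)methyl on a saturated chain carbon, three bonds along the chain from an amide-type nitrogen, which is the same change that led from compound 2 to compound 1. The step from compound 3 to compound 4 is expected to be no change at the digits printed from compound 3 to compound 4 (within the scatter) because the same change gave no change at the digits printed from compound 2 to compound 1 (within the scatter). Among the compounds with values here, only one earlier example of the change is known, and it was made on a core whose relation to the core of compound 3 is not broken down, so the range kept around the estimate is wide. Compound 4 is therefore estimated to give 4600 nM in this assay, with the expected span reaching from 2300 nM to 9200 nM.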

Compound 4, half-maximal inhibitory concentration: 4600 nM
For compound 4 middle estimate and measured number coincide at the digits printed, within the range that was stated.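

In this assay, replacing the 4-(hydroxycarbamoyl)butyl chain of compound 3 with the 3-(hydroxycarbamoyl)propyl chain of compound 4 makes a step of no change at the digits printed from compound 3 to compound 4 (within the scatter). Set beside the earlier example, the change reads the same on both cores, so in this small set it carries from one core to the other: the same change on two cores in this assay, no change at the digits printed (within the scatter) from compound 2 to compound 1 and no change at the digits printed (within the scatter) from compound 3 to compound 4, 1.0-fold (0.00 log units) apart, within the scatter of two such steps. Within the data shown here, this rests on only two pairs and on a step with no measurable size, so it shows that the chain swap leaves the reading in place on these two cores, but it does not show that the same would hold on any other core, nor does it explain why the reading stays put.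

The compounds shown leave open how far the chain can vary before the reading moves, for example with a 2-(hydroxycarbamoyl)ethyl chain or a longer chain such as 5-(hydroxycarbamoyl)pentyl. They also leave open what happens when the hydroxycarbamoyl end itself is replaced, for instance by a carboxylic acid or an amine, since every compound here carries that same end.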